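This account rests on a few compounds, and the source may have more. Where it says the series, first, only, none or still open, it means among the compounds named here.

Three compounds have been measured so far in a physicochemical assay for solubility, in phosphate buffer, at pH 7.4 (on this read-out higher numbers stand for higher solubility and lower numbers for lower solubility), as follows:

Compound 1 `OCC1CCN(c2nccnc2OC2CN(c3nc4ccccc4s3)C2)CC1` gives 31000 nM
Compound 2 `OCC1CCN(c2nccnc2OC2CN(c3cnc4ccccc4n3)C2)CC1` gives 500000 nM
Compound 3 `OC1CN(c2nccnc2OC2CN(c3ccc4ccccc4n3)C2)C1` gives 41000 nM

Compound 3 at 41000 nM lies within the usual scatter of compound 1 at 31000 nM and cannot be told apart from it. Compound 2 at 500000 nM stands higher than compound 3, well beyond the scatter. Among the compounds with values here, these three compounds differ in more than one place, so no measured step isolates a single change.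

Still unmeasured is compound 4 `c1ccc2nc(N3CC(Oc4nccnc4N4CCCCC4)C3)ccc2c1` in which piperidin-1-yl stands in place of 3-hydroxyazetidin-1-yl on an aromatic carbon (piperidin-1-yl in place of 3-hydroxyazetidin-1-yl on an aromatic carbon) while the rest of compound 3 is kept. Within the data shown here, with no measured precedent for this swap, the expectation in this assay rests on the structural change alone and is a judgement, not a trend. A moderate fall beyond the scatter is expected, starting from compound 3 at 41000 nM as the reference. The expected size of the change is a 5.1-fold lower number from compound 3 to compound 4 (0.71 log units; beyond the scatter) in the downward direction. The estimate for compound 4 is 8000 nM with an expected range of 1500 nM to 30000 nM as the likely span.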

Compound 4, solubility: < 1000 nM
Compound 4: no number, only a limit; the forecaster's own chance of this, stated with the estimate: 5%; middle value at least 8.0-fold (0.90 log units) from the limit.
By their numbers in this assay, from the lowest: compounds 1 and 3 (each within the scatter of the next); then compound 2. At a limit, below all of these: compound 4.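

Within the data shown here, this is the first step that isolates a single place: on an aromatic carbon of a six-membered aromatic ring with 2 nitrogen, piperidin-1-yl in place of 3-hydroxyazetidin-1-yl gives an at least 41-fold lower number from compound 3 to compound 4 (1.61 log units; beyond the scatter) in this assay. From the compounds shown here alone, compound 4 gives < 1000 nM, which is a limit of the assay and not a number, so the step is large but its full size stays unknown: the limit of < 1000 nM in this assay, at which 1 of the 4 values shown sits. The swap changes several counted features at once, going from a four-membered to a six-membered non-aromatic ring and from one hydrogen-bond donor to none, and this single step does not separate them.

Going by these compounds, whether a 4-hydroxypiperidin-1-yl or a morpholin-4-yl group on that same carbon would stand nearer to compound 3 or to compound 4 in this assay remains open. Also open, on these data alone, is how a piperidine ring carrying a carboxylic acid or a primary amine would read there, and whether the step would be of similar size on the cores of compound 1 and compound 2.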